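This account rests on a few compounds, and the source may have more. Where it says the series, first, only, none or still open, it means among the compounds named here.

Compound 2 `O=C(c1ccncc1)n1c(-c2cn(-c3ccccc3)nc2-c2ccc(F)cc2)nc2ccccc21` gives 151000 nM in an ADME assay on HEK-293T cells (Homo sapiens) for cytotoxicity, read by MTT assay, with a stated time of 24 h; a lower number here means that less compound is tolerated, a higher number that more compound is tolerated.
Compound 1 `Cc1ccc(C(=O)n2c(-c3cn(-c4ccccc4)nc3-c3ccc(C(F)(F)F)cc3)nc3ccccc32)cc1` gives 169000 nM in this assay.

Compound 2 holds the lowest of the two numbers, yet its nearest neighbour, compound 1, stands within the scatter of it, so the two values show no order between them. Compound 3 `O=C(c1ccncc1)n1c(-c2cn(-c3ccccc3)nc2-c2ccc(C(F)(F)F)cc2)nc2ccccc21` has not been measured in this assay. It differs from compound 2 by trifluoromethyl in place of fluoro on an aromatic carbon. For the measured compounds named here, no step between two measured compounds isolates this change, so its effect cannot be read directly. Compound 1, which carries the same trifluoromethyl group on a different core, gives 169000 nM, a number within the scatter of compound 2, and nothing in these data points to a shift beyond it. Compound 3 is therefore expected to show a step of a 1.0-fold higher number from compound 2 to compound 3 (0.01 log units; within the scatter), which is no step beyond the scatter. The estimate for compound 3 in this assay is 155000 nM, with a range from 80000 nM to 300000 nM.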

Compound 3, half-maximal cytotoxic concentration: 135000 nM
For compound 3 the middle estimate is 1.1-fold (0.06 log units) above the measured one, within the range that was stated.
By their numbers in this assay, from the lowest: compounds 3, 2 and 1 (each within the scatter of the next).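

In this assay, the change from fluoro to trifluoromethyl on this aromatic carbon, para to a large group, can now be read directly, with a 1.1-fold lower number from compound 2 to compound 3 (0.05 log units; within the scatter), so the swap at this position gives no difference that stands out from the scatter. Compound 3 also connects to compound 1 through the group on the carbonyl carbon, where pyridin-4-yl in place of 4-methylphenyl gives a 1.3-fold lower number from compound 1 to compound 3 (0.10 log units; within the scatter), so this second change also remains within the scatter. The data shown offer no measured account of either result.

The compounds shown carry only fluoro or trifluoromethyl at this position, so they leave open whether a group of another kind, such as an amine or a carboxylic acid, would shift the number beyond the scatter.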